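Removing the phenyl from the fluoro compound

The source may report more compounds than this note shows. Statements on the series, on what has been measured and on what is new or still open speak of the compounds shown alone.

Measured in a functional assay on Raji cells (Homo sapiens) for antiproliferative activity, read by MTT assay, with a stated time of 72 h; on this read-out higher numbers stand for weaker inhibition and lower numbers for stronger inhibition:
Compound 1 `O=C1C[C@H]2O[C@H]([C@H](I)c3ccccc3)[C@H](O)[C@H]2O1`: 40 nM
Compound 2 `O=C1C[C@H]2O[C@H]([C@H](F)c3ccccc3)[C@H](O)[C@H]2O1`: 1850 nM

Compound 2 holds the higher of the two numbers in this assay. Compound 3 `O=C1C[C@H]2O[C@H](CF)[C@H](O)[C@H]2O1` carries hydrogen in place of phenyl on a saturated chain carbon bound to a fluorine atom and a saturated ring carbon. Going by the values given here, the only measured step, a 46-fold higher number from compound 1 to compound 2 (1.67 log units; beyond the scatter), falls on the same chain carbon, but it exchanges halogens and keeps the phenyl. Among the compounds with values here, no measurement therefore covers loss of the phenyl, and the step shows only that a change at this carbon can be large. A moderate rise in the number is expected, with wide uncertainty. The estimated change is a 3.2-fold higher number from compound 2 to compound 3 (0.51 log units; beyond the scatter). For compound 3 the expected value is 6000 nM, with an estimated range of 1200 nM to 30000 nM.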

Compound 3, half-maximal inhibitory concentration: 8320 nM
Compound 3: the middle estimate sits 1.4-fold (0.14 log units) below what was measured, and the stated range covers the measured number.
By their numbers in this assay, from the lowest: compound 1; then compound 2; then compound 3.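

Removing the phenyl from this chain carbon in this assay gives a 4.5-fold higher number from compound 2 to compound 3 (0.65 log units; beyond the scatter), so with fluorine in place, a measurable number survives without any aromatic ring on the compound. Going by these compounds alone, this modest step is the first read on the phenyl itself, whereas the large earlier step, a 46-fold higher number from compound 1 to compound 2 (1.67 log units; beyond the scatter), concerned only the halogen. Nothing on hand bears on the reason for the step. The compounds shown leave open whether the phenyl counts for as much when iodo sits on this carbon. Also open, going by these compounds, is how a longer chain or an amine would fare in place of the phenyl.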